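The compounds below may be only part of what the source reports. "The series", "measured", "known", "first", "only" and "open" are said of these compounds alone.

Measured in an assay on cells for inhibition of Amine oxidase [flavin-containing] B (Homo sapiens), read by fluorescence and Amplex Red, with a stated time of 15 min; a lower number here means a stronger inhibitor, a higher number a weaker inhibitor:

compound 1 `Cc1ccc2oc(=O)c(-c3ccc(Br)nn3)cc2c1` gives 2160 nM
compound 2 `Cc1ccc2cc(-c3ccc(Br)nn3)c(=O)oc2c1` gives 750 nM
compound 3 `Cc1ccc2oc(=O)c(-c3ccc(Cl)nn3)cc2c1` gives 13500 nM

Compound 2 has the lowest number of the three; compound 1 and compound 3 lie further up. Compound 1 and compound 2 share the same atoms joined differently, and the difference between the two cores is not broken down here.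

From compound 1 to compound 3 the change is chloro in place of bromo on an aromatic carbon, and it gives a 6.3-fold higher number from compound 1 to compound 3 (0.80 log units; beyond the scatter). Compound 4 `Cc1ccc2cc(-c3ccc(Cl)nn3)c(=O)oc2c1` is not yet measured in this assay; it differs from compound 2 by chloro in place of bromo on an aromatic carbon, the same change seen from compound 1 to compound 3. On that one step compound 4 is expected to show a 6.0-fold higher number from compound 2 to compound 4 (0.78 log units; beyond the scatter). This expectation rests on the value of compound 2, 750 nM, and on a 6.3-fold higher number from compound 1 to compound 3 (0.80 log units; beyond the scatter). The estimate for compound 4 in this assay is 4500 nM, expected to fall between 1800 nM and 12000 nM.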

Compound 4, half-maximal inhibitory concentration: 2510 nM
For compound 4 the middle estimate is 1.8-fold (0.25 log units) above the measured one, within the range that was stated.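

In this assay, chloro in place of bromo on an aromatic carbon again gives a weaker inhibitor, with a 3.3-fold higher number from compound 2 to compound 4 (0.52 log units; beyond the scatter). The change carries across the two cores in direction, and its size does not differ measurably between them: the same change on two cores in this assay, a 6.3-fold higher number (0.80 log units; beyond the scatter) from compound 1 to compound 3 and a 3.3-fold higher number (0.52 log units; beyond the scatter) from compound 2 to compound 4, 1.9-fold (0.27 log units) apart, within the scatter of two such steps. For the compounds shown here, with only two pairs in one assay, this supports transfer between these two cores alone; it sets no rule for other cores and does not explain the loss.

Going by these compounds, it remains open whether another group at this place on the ring, such as an amine or a nitrile, would give a lower number than compound 2. On these data alone, the effect of replacing the methyl group, present in all four compounds, with a longer chain is also open.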